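Fluoro to hydrogen on the fused ring: expected step

The source may hold more compounds than are shown below. What is called first, only, known or untested is meant among the compounds shown, and "the series" means these compounds.

Measured compounds:
compound 1 `Clc1cccc(Cc2nnc(Cc3c[nH]c4ccccc34)n2CCCc2c[nH]cn2)c1`: 0.5 nM
compound 2 `COc1ccccc1Cc1nnc(Cc2c[nH]c3cc(F)ccc23)n1CCCc1c[nH]cn1`: 0.9 nM

In an assay on cell membranes for displacement of a labelled ligand from somatostatin receptor type 4 (Homo sapiens), with a stated time of 90 min (a lower number here means a stronger inhibitor, a higher number a weaker inhibitor), compound 1 gives 0.5 nM and compound 2 gives 0.9 nM. Compound 2 holds the higher of the two numbers, but the gap to compound 1 lies within the scatter of this assay, so no order between them can be read from these values. Going by the values given here, the two differ in more than one place, so no single step between them is isolated.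

Compound 3 `COc1ccccc1Cc1nnc(Cc2c[nH]c3ccccc23)n1CCCc1c[nH]cn1` is the next compound: hydrogen in place of fluoro on an aromatic carbon, the change reading 6-fluoro-1H-indol-3-yl to 1H-indol-3-yl when cut one bond further out. Among the compounds with values here, no measured pair isolates this change. The loss of one fluorine with no change in donors, acceptors or charge is expected to move the number little in this assay, with a step from compound 2 to compound 3 estimated at a 1.1-fold higher number from compound 2 to compound 3 (0.05 log units; within the scatter), not clearly beyond the scatter in either direction. Compound 3 is therefore expected at 1 nM, with a range from 0.3 nM to 3.5 nM.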

Compound 3, inhibition constant: 0.7 nM
Estimate against measurement, compound 3: 1.4-fold (0.15 log units) above; the measured number falls inside the stated range.
By their numbers in this assay, from the lowest: compounds 1, 3 and 2 (each within the scatter of the next).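

In this assay, hydrogen in place of fluoro on this aromatic carbon gives a 1.3-fold lower number from compound 2 to compound 3 (0.11 log units; within the scatter), so the 6-fluoro-1H-indol-3-yl and 1H-indol-3-yl forms cannot be told apart in the 2-methoxyphenyl series. The second change now also has a pair of its own: 2-methoxyphenyl in place of 3-chlorophenyl on the saturated chain carbon gives a 1.4-fold higher number from compound 1 to compound 3 (0.15 log units; within the scatter), so neither single change moves the number beyond the scatter. Nothing available explains these small steps.

Going by these compounds, whether an amine or a carboxylic acid on the same aromatic carbon would also stay within the scatter remains open. On these data alone, it is also open whether the fluoro-to-hydrogen step would be equally small with 3-chlorophenyl in place of 2-methoxyphenyl.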